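Geometry switch on a chlorinated analogue

The source may hold more compounds than are shown below. What is called first, only, known or untested is meant among the compounds shown, and "the series" means these compounds.

Measured compounds:
compound 1 `O=S(=O)(/C=C\c1cccnc1)c1cccc(F)c1` with 4820 nM
compound 2 `O=S(=O)(/C=C/c1ccc(Cl)nc1)c1cccc(F)c1` with 4870 nM

In an assay on U2OS cells for activation of nuclear factor erythroid 2-related factor 2 (Homo sapiens), read by beta-arrestin recruitment, with a stated time of 6 h (on this read-out lower numbers stand for an effect already at smaller amounts and higher numbers for an effect only at larger amounts of compound), compound 1 gives 4820 nM. In this assay compound 2 gives 4870 nM. Compound 2 differs from compound 1 in several places at once. Compound 2 has the highest of the two numbers, but its nearest neighbour is compound 1, whose number is within the scatter of its own, so the two compounds cannot be told apart on this read-out.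

The step under consideration leads from compound 2 to compound 3 `O=S(=O)(/C=C\c1ccc(Cl)nc1)c1cccc(F)c1`, which has yet to be tested in this assay. How compound 3 differs from compound 2: the two compounds have the same atoms and bonds and differ only in configuration as drawn: 1 of 1 stereo elements differ; a double bond is drawn E in compound 2 and Z in compound 3.

Going by the values given here, no pair of measured compounds isolates a change of double-bond configuration with everything else held constant, so the data offer no direct measure of what such a step does. Given that compound 1 and compound 2, drawn with opposite configuration, sit within the scatter of each other, compound 3 is expected to give 4900 nM in this assay, with a range of 1600 nM to 15000 nM. The step from compound 2 to compound 3 is therefore estimated to be a 1.0-fold higher number from compound 2 to compound 3 (0.00 log units; within the scatter), that is, nothing beyond the scatter.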

Compound 3, half-maximal effective concentration: 965 nM
Compound 3: the middle estimate sits 5.1-fold (0.71 log units) above what was measured; measured number below the stated range.
By their numbers in this assay, from the lowest: compound 3; then compounds 1 and 2 (each within the scatter of the next).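

In this assay, going by these compounds alone, switching the double bond from E to Z on the chlorinated compounds gives a 5.0-fold lower number from compound 2 to compound 3 (0.70 log units; beyond the scatter), the first measured step that isolates this configuration. The shift belongs to the double bond alone, because nothing else separates the two compounds: the fact that compounds 2 and 3 differ only in the configuration as drawn With the double bond drawn Z in both compounds, chloro in place of hydrogen on an aromatic carbon gives a 5.0-fold lower number from compound 1 to compound 3 (0.70 log units; beyond the scatter), so the chloro also makes a measurable difference, something the earlier pair could not show, as it differed in several places at once and its values lay within the scatter.

The compounds shown leave open whether the change from E to Z would have a step of similar size on a compound without the chloro, as the only such comparison here is on the chlorinated pair. Within the data shown here, they also leave open whether the chloro is the only group that gives this step on the Z compounds, or whether a methoxy group, an amine or a nitrile in its place would do the same.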